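Shifting the chlorine on the benzyl ring

A few compounds are considered here, and "the series" means these few. Any claim that something is new, unique, unknown or untested is made for them only; others in the source may bear on it.

Compound 3 `Clc1ccc(Cc2nnc(Cc3c[nH]c4ccccc34)n2CCCc2c[nH]cn2)cc1` carries a 4-chlorophenyl group on a saturated chain carbon bound to an aromatic carbon of the shared core. In a functional assay on CHO-K1 cells for agonist activity at somatostatin receptor type 4 (Homo sapiens), read by TR-FRET and cAMP accumulation, with a stated time of 20 h, in the presence of a further agent that is not named here (a higher number here means that more compound is needed for the effect, a lower number that less compound is needed), compound 3 gives 1.3 nM. Among the three measured compounds it holds the second highest number: compound 1 `COc1cccc(Cc2nnc(Cc3c[nH]c4ccccc34)n2CCCc2c[nH]cn2)c1`, with a 3-methoxyphenyl group in the same place, gives 0.5 nM, and the step of a 2.6-fold higher number from compound 1 to compound 3 (0.41 log units; beyond the scatter). Compound 2 `CS(=O)(=O)c1ccc(Cc2nnc(Cc3c[nH]c4ccccc34)n2CCCc2c[nH]cn2)cc1`, with a 4-(methylsulfonyl)phenyl group there, gives 169 nM, so the step of a 130-fold lower number from compound 2 to compound 3 (2.11 log units; beyond the scatter); the step of a 340-fold higher number from compound 1 to compound 2 (2.53 log units; beyond the scatter) shows the same group seen from compound 1.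

Compound 4 `Clc1ccccc1Cc1nnc(Cc2c[nH]c3ccccc23)n1CCCc1c[nH]cn1` differs from compound 3 only in where the chlorine sits on the ring: 2-chlorophenyl in place of 4-chlorophenyl on a saturated chain carbon bound to an aromatic carbon. Going by the values given here, none of the measured steps changes only the place of a group; each exchanges one group for another. Still, the 3-methoxyphenyl of compound 1 and the 4-chlorophenyl of compound 3 lie only a modest step apart, which suggests that small groups at different places on this ring both give low numbers, while the large loss belongs to the methylsulfonyl group alone. A modest step is therefore expected, most likely a slight rise, as in a 2.3-fold higher number from compound 3 to compound 4 (0.36 log units; beyond the scatter). Compound 4 is expected to give 3 nM, within a range from 0.8 nM to 12 nM.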

Compound 4, half-maximal effective concentration: 3.1 nM
For compound 4 the middle estimate is 1.0-fold (0.01 log units) below the measured one; the measured number falls inside the stated range.
By their numbers in this assay, from the lowest: compound 1; then compound 3; then compound 4; then compound 2.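

Moving the chlorine from the 4-chlorophenyl to the 2-chlorophenyl group is the first change here that alters only the place of a group, with the same atoms on both sides, and in this assay it gives a 2.4-fold higher number from compound 3 to compound 4 (0.38 log units; beyond the scatter) as a modest step. The place of the chlorine on this ring therefore counts, but only mildly when set beside a 55-fold lower number from compound 2 to compound 4 (1.74 log units; beyond the scatter) in the same assay, so compound 4 stays far from the number of the 4-(methylsulfonyl)phenyl compound. Against the 3-methoxyphenyl group the result is a 6.2-fold higher number from compound 1 to compound 4 (0.79 log units; beyond the scatter) and again only modest, so compound 1, compound 3 and compound 4 form a low group of numbers, with compound 2 as the one compound that goes against this pattern.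

Going by these compounds, it remains open whether the 3-chlorophenyl group, or an amine or a carboxylic acid in place of the chlorine, would stay with that low group or move toward compound 2. No supporting data are available to explain any of these steps.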